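From pyridin-3-yl to 2-chloropyridin-4-yl on the shared core

The compounds below may be only part of what the source reports. "The series", "measured", "known", "first", "only" and "open" are said of these compounds alone.

In a toxicity assay on THP-1 cells (Homo sapiens) for cytotoxicity, read by luminescence and CellTiter-Glo, with a stated time of 72 h (on this read-out lower numbers stand for higher toxicity in this test and higher numbers for lower toxicity in this test), three compounds with a shared core have been measured. Compound 1 (`Cc1ccc(-c2ccnc(Nc3ccc(N4CCN(C)CC4)c(C(F)(F)F)c3)n2)cc1`) gives 4940 nM and compound 2 (`CN1CCN(c2ccc(Nc3nccc(-c4cccc(Cl)c4)n3)cc2C(F)(F)F)CC1`) gives 5280 nM on this read-out. Compound 3 (`CN1CCN(c2ccc(Nc3nccc(-c4cccnc4)n3)cc2C(F)(F)F)CC1`) gives 1060 nM as the lowest number of the three. Compound 4 (`CN1CCN(c2ccc(Nc3nccc(-c4ccnc(Cl)c4)n3)cc2C(F)(F)F)CC1`) differs from compound 3 at a single place (2-chloropyridin-4-yl in place of pyridin-3-yl on an aromatic carbon), with 2-chloropyridin-4-yl in place of pyridin-3-yl on an aromatic carbon.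

All three measured steps change this same position. Putting 3-chlorophenyl in place of 4-methylphenyl gave a 1.1-fold higher number from compound 1 to compound 2 (0.03 log units; within the scatter) as the result. Putting pyridin-3-yl in place of 4-methylphenyl gave a 4.7-fold lower number from compound 1 to compound 3 (0.67 log units; beyond the scatter) as the result, and putting it in place of 3-chlorophenyl gave a 5.0-fold lower number from compound 2 to compound 3 (0.70 log units; beyond the scatter) as the result. Within the data shown here, compound 4 keeps a pyridine ring like compound 3 but carries a chlorine like compound 2, and no measured compound combines the two. A modest rise is therefore expected, probably not the whole of the gap between these two compounds. The expected change is a 2.5-fold higher number from compound 3 to compound 4 (0.39 log units; beyond the scatter) by this estimate. Compound 4 is estimated at 2600 nM with an expected range from 1000 nM to 6500 nM for the coming measurement.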

Compound 4, half-maximal cytotoxic concentration: 1140 nM
Estimate against measurement, compound 4: 2.3-fold (0.36 log units) above; measured number inside the range.
By their numbers in this assay, from the lowest: compounds 3 and 4 (each within the scatter of the next); then compounds 1 and 2 (each within the scatter of the next).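

In this assay, the move from pyridin-3-yl to 2-chloropyridin-4-yl gave a 1.1-fold higher number from compound 3 to compound 4 (0.03 log units; within the scatter), so this position tolerated the added chlorine and the new place of the ring nitrogen together without a change beyond the scatter. The same group stood well apart from the two phenyl groups, with a 4.6-fold lower number from compound 2 to compound 4 (0.67 log units; beyond the scatter) and a 4.3-fold lower number from compound 1 to compound 4 (0.64 log units; beyond the scatter), so that across these four compounds the number followed the presence of a pyridine ring rather than a chlorine, and none of the four goes against this. No measurement given here explains this grouping.

Since the chlorine and the new place of the ring nitrogen arrive in a single step, the compounds shown leave open whether each alone would also leave the number unmoved, which a plain pyridin-4-yl or a 2-chloropyridin-3-yl group would address. They also leave open whether the grouping holds for pyridine rings carrying another substituent, such as an amine or a methoxy group, at this position.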